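This account rests on a few compounds, and the source may have more. Where it says the series, first, only, none or still open, it means among the compounds named here.

For the measured compounds named here, in a functional assay on SK-OV-3 cells (Homo sapiens) for inhibition, read by CCK-8 assay, with a stated time of 70 h (a lower number here means a stronger inhibitor, a higher number a weaker inhibitor), compound 1 `OCCOCCOCCOc1ccc(OCc2ccccc2)cc1` gives 59400 nM, while compound 2 `c1ccc(COc2ccc(OCCOCCNC3CCC3)cc2)cc1` gives 25000 nM, the lowest of the numbers measured so far. Compound 3 `c1ccc(COc2ccc(OCCOCCNC3CCCCCC3)cc2)cc1` keeps the rest of compound 2 and carries cycloheptyl in place of cyclobutyl on an amine nitrogen. Going by the values given here, no measured pair varies the ring on that nitrogen. Among the compounds with values here, the only measured step, a 2.4-fold lower number from compound 1 to compound 2 (0.38 log units; beyond the scatter), belongs to a different change, cyclobutylamino in place of 2-hydroxyethoxy, and it was modest. It therefore offers only a loose guide to size and none to direction. A modest step towards a lower number is nevertheless expected in this assay, with little support for that direction. The expected change is a 1.9-fold lower number from compound 2 to compound 3 (0.28 log units; within the scatter). Compound 3 is estimated at 13000 nM, with an expected range from 4500 nM to 35000 nM.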

Compound 3, half-maximal inhibitory concentration: 7460 nM
Estimate against measurement, compound 3: 1.7-fold (0.24 log units) above; the measured number falls inside the stated range.
By their numbers in this assay, from the lowest: compound 3; then compound 2; then compound 1.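

In this assay, for the compounds shown here, the ring on the amine nitrogen proves to matter: with the rest of the molecule unchanged, cycloheptyl in place of cyclobutyl gives a 3.4-fold lower number from compound 2 to compound 3 (0.53 log units; beyond the scatter), the first measured step at this position. Measured against the 2-hydroxyethoxy end of compound 1, the cycloheptylamino group now gives an 8.0-fold lower number from compound 1 to compound 3 (0.90 log units; beyond the scatter), a larger step than the cyclobutylamino group gave. Nothing available accounts for this difference between the two rings.

Going by these compounds alone, with only two ring sizes on that nitrogen, it remains open whether the number falls steadily as the ring grows, and cyclopentyl or cyclohexyl would show whether it does. As far as these compounds go, whether a ring is needed at all also remains open, a question that an open-chain group such as n-hexyl on the same nitrogen could address.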